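This account rests on a few compounds, and the source may have more. Where it says the series, first, only, none or still open, it means among the compounds named here.

Measured compounds:
compound 1, `Cc1ccccc1-n1nncc1CN1C(=O)C2(C(C#N)=C(N)Oc3c2c2nc4ccccc4nc2c2ccccc32)c2ccccc21`, > 50000 nM (a limit)
compound 2, `CC(=O)Nc1ccc(-n2nncc2CN2C(=O)C3(C(C#N)=C(N)Oc4c3c3nc5ccccc5nc3c3ccccc43)c3ccccc32)cc1`, > 50000 nM (a limit)
compound 3, `Cc1ccc(-n2nncc2CN2C(=O)C3(C(C#N)=C(N)Oc4c3c3nc5ccccc5nc3c3ccccc43)c3ccccc32)cc1C`, > 50000 nM (a limit)

In a functional assay on HCT-116 cells (Homo sapiens) for antiproliferative activity, read by MTT assay, with a stated time of 48 h (a higher number here means a weaker inhibitor, a lower number a stronger inhibitor), compound 1 stands at a limit and not at a number, > 50000 nM. Compound 2 also sits at the limit of this assay, > 50000 nM. Compound 3 sits at the same limit, > 50000 nM. Compound 4 is `N#CC1=C(N)Oc2c(c3nc4ccccc4nc3c3ccccc23)C12C(=O)N(Cc1cnnn1-c1ccc(F)c(Cl)c1)c1ccccc12`; it differs from compound 1 by 3-chloro-4-fluorophenyl in place of 2-methylphenyl on an aromatic nitrogen. The steps that exchange the aryl group on that same nitrogen, a step that the two limits leave unreadable from compound 1 to compound 2, a step that the two limits leave unreadable from compound 1 to compound 3 and a step that the two limits leave unreadable from compound 2 to compound 3, give no readable size because of the limit of > 50000 nM in this assay, at which 3 of the 3 values shown sit. For the measured compounds named here, no measured step can therefore set a size or direction for the change in this assay. Compound 4 is expected to remain at the limit, so the expected step of a number no higher from compound 1 to compound 4 (the limit leaves the size open) is one that cannot be read. The estimate for compound 4 is 50000 nM, with a range from 20000 nM to 200000 nM.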

Compound 4, half-maximal inhibitory concentration: > 50000 nM
Compound 4: only a limit was reported (the forecaster's own chance of this, stated with the estimate: 85%); the middle value lies on the limit itself.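

Compound 4, like compound 1, compound 2 and compound 3, gives only a limit, so no step among these compounds can be read in this assay: the limit of > 50000 nM in this assay, at which 4 of the 4 values shown sit.

On these data alone, whether any aryl group on that aromatic nitrogen gives a number rather than a limit stays open.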